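Replacing 3-chlorobenzyl with 4-chlorophenyl in compound 2

The source may hold more compounds than are shown below. What is called first, only, known or untested is meant among the compounds shown, and "the series" means these compounds.

Going by the values given here, in a functional assay on K562 cells (Homo sapiens) for inhibition, read by fluorescence, with a stated time of 72 h (on this read-out higher numbers stand for weaker inhibition of growth and lower numbers for stronger inhibition of growth), compound 2 (`CCCCn1cnc2c(NCc3cccc(Cl)c3)nc(N[C@H]3CC[C@H](N)CC3)nc21`) gives 4300 nM as the higher of the two numbers so far. Compound 1 (`CCCCCCn1cnc2c(Nc3ccc(Cl)cc3)nc(N[C@H]3CC[C@H](N)CC3)nc21`), which carries 4-chlorophenyl, gives 2100 nM and sits lower by a gap just beyond the scatter. Compound 3 (`CCCCn1cnc2c(Nc3ccc(Cl)cc3)nc(N[C@H]3CC[C@H](N)CC3)nc21`) has 4-chlorophenyl in place of 3-chlorobenzyl on a nitrogen on an aromatic ring. Among the compounds with values here, no measured step isolates this change, so the expectation rests on those two values alone. In this assay a modest move toward stronger inhibition of growth is expected (a 2.0-fold lower number from compound 2 to compound 3 (0.29 log units; within the scatter)). For compound 3 the estimated value is 2200 nM (range 800 nM to 5500 nM).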

Compound 3, concentration for 50% growth inhibition: 2700 nM
Compound 3: the middle estimate sits 1.2-fold (0.09 log units) below what was measured, and the stated range covers the measured number.
By their numbers in this assay, from the lowest: compounds 1, 3 and 2 (each within the scatter of the next, the first and the last beyond it).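

In this assay the swap of 3-chlorobenzyl for 4-chlorophenyl on this nitrogen on an aromatic ring gives no readable shift (a 1.6-fold lower number from compound 2 to compound 3 (0.20 log units; within the scatter)). The chain change, hydrogen in place of ethyl four bonds along the chain from an aromatic nitrogen, likewise stays within the scatter (a 1.3-fold higher number from compound 1 to compound 3 (0.11 log units; within the scatter)), so the gap between compound 1 and compound 2 is not traced to either single change. No evidence on the cause of these results is available.

Still open, going by these compounds, is what 3-chlorophenyl, 4-chlorobenzyl or unsubstituted benzyl would give on this nitrogen. On these data alone, an octyl chain in place of the butyl of compound 3 is also open.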